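The source may report more compounds than this note shows. Statements on the series, on what has been measured and on what is new or still open speak of the compounds shown alone.

The shared core is a fused two-ring system carrying a varied aryl group. Compound 1 `CCCc1ccc(-c2cc(=O)c3c(o2)C(CC)(CC)C(=O)C(CC)=C3O)cc1` carries 4-propylphenyl; in a functional assay on KB cells (Homo sapiens) for antiproliferative activity, read by sulforhodamine B assay, with a stated time of 3 days (a lower number here means that less compound is needed, a higher number that more compound is needed for the effect), compound 1 gives only a limit, > 53 uM. Compound 2 `CCC1=C(O)c2c(oc(-c3cccc(F)c3)cc2=O)C(CC)(CC)C1=O` carries 3-fluorophenyl, and in this assay compound 2 also gives only a limit, > 56.2 uM. Going by the values given here, compound 3 `CCC1=C(O)c2c(oc(-c3ccc(C)c(F)c3)cc2=O)C(CC)(CC)C1=O`, with 3-fluoro-4-methylphenyl, gives 28.1 uM, the only number among the three. Compound 4 `CCC1=C(O)c2c(oc(-c3cccc(C)c3C)cc2=O)C(CC)(CC)C1=O` differs from compound 3 as follows: 2,3-dimethylphenyl in place of 3-fluoro-4-methylphenyl on an aromatic carbon. The nearest measured steps are an at least 2.0-fold lower number from compound 2 to compound 3 (0.30 log units; that floor lies within the scatter) and an at least 1.8-fold lower number from compound 1 to compound 3 (0.27 log units; that floor lies within the scatter), both floors within the scatter. Neither step tests the removal of the fluorine or the placement of two methyl groups, so the change is largely untested. Compound 4 is therefore expected to sit near compound 3, with a step of a 1.2-fold higher number from compound 3 to compound 4 (0.10 log units; within the scatter). Compound 4 is estimated at 35 uM, between 12 uM and 100 uM.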

Compound 4, concentration for half-maximal effect: 3.1 uM
Compound 4: middle estimate off by 11-fold (1.05 log units), on the high side; the measured number lies below the stated range.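

Going by these compounds alone, changing the aryl group at this position can matter much more than the earlier compounds showed: 2,3-dimethylphenyl in place of 3-fluoro-4-methylphenyl gives a 9.1-fold lower number from compound 3 to compound 4 (0.96 log units; beyond the scatter), the first measured step beyond the scatter. Compared with the two compounds known only by limits, the same group gives an at least 18-fold lower number from compound 2 to compound 4 (1.25 log units; beyond the scatter) and an at least 17-fold lower number from compound 1 to compound 4 (1.23 log units; beyond the scatter), so those sizes are floors, not exact values.

From the compounds shown here alone, whether the drop needs both methyl groups or the loss of fluorine stays open, as does how an amine or a methoxy group on this phenyl ring would read in this assay. Nothing shown here explains the size of this step.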